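Amide aryl swap in the series: cytotoxicity outlook

The source may hold more compounds than are shown below. What is called first, only, known or untested is meant among the compounds shown, and "the series" means these compounds.

Compound 3 `COc1ccc2c(=O)c(/C=C/C(=O)Nc3ccccc3C)coc2c1` gives 59700 nM in an ADME assay on HepG2 2.2.15 cells (Homo sapiens) for cytotoxicity, read by MTT assay, with stated times of 48 h and 9 days (on this read-out higher numbers stand for lower toxicity in this test and lower numbers for higher toxicity in this test), the lowest of the three numbers in hand. Compound 1 `COc1ccc2c(=O)c(/C=C/C(=O)Nc3cccc(Cl)c3)coc2c1` gives 1100000 nM in this assay, and compound 2 `COc1ccc2c(=O)c(/C=C/C(=O)Nc3cc(C)ccc3C)coc2c1` gives 1100000 nM. The two steps that arrive at compound 3 are both large: an 18-fold lower number from compound 1 to compound 3 (1.27 log units; beyond the scatter) and an 18-fold lower number from compound 2 to compound 3 (1.27 log units; beyond the scatter), whereas no change at the digits printed from compound 1 to compound 2 (within the scatter). Compound 4 `COc1ccc2c(=O)c(/C=C/C(=O)Nc3ccc(F)cc3)coc2c1` differs from compound 3 by 4-fluorophenyl in place of 2-methylphenyl on an amide-type nitrogen. This removes the 2-methylphenyl that sets compound 3 apart and brings in a halogen-bearing ring, as compound 1 carries, so a return toward the higher numbers is expected in this assay, of about the size seen on entering compound 3 but reversed. The step expected is an 8.4-fold higher number from compound 3 to compound 4 (0.92 log units; beyond the scatter). Compound 4 is estimated at 500000 nM, with a range from 100000 nM to 1500000 nM.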

Compound 4, half-maximal cytotoxic concentration: 743000 nM
Compound 4: the middle estimate sits 1.5-fold (0.17 log units) below what was measured; the measured number falls inside the stated range.
By their numbers in this assay, from the lowest: compound 3; then compounds 4, 1 and 2 (each within the scatter of the next).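

In this assay the low number of compound 3 does not carry over to 4-fluorophenyl on the amide-type nitrogen (a 12-fold higher number from compound 3 to compound 4 (1.10 log units; beyond the scatter)). Compound 4 instead stands level with the other two (a 1.5-fold lower number from compound 2 to compound 4 (0.17 log units; within the scatter); a 1.5-fold lower number from compound 1 to compound 4 (0.17 log units; within the scatter)), so three different aryl groups now match and 2-methylphenyl alone stands apart, although 2,5-dimethylphenyl in compound 2 does not share its low number. No measurement available here explains this.

Open, on these data alone, is where unsubstituted phenyl would fall. Also open, as far as these compounds go, is whether an aminophenyl or a carboxyphenyl on this nitrogen would match compound 3 or the other three.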